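Replacing the chlorophenyl arm of a hydrazone with hydroxynaphthyl

The source may report more compounds than this note shows. Statements on the series, on what has been measured and on what is new or still open speak of the compounds shown alone.

Measured compounds:
Compound 1 `CCCSc1nc(N/N=C/c2ccccc2Cl)c2nnn(Cc3ccccc3)c2n1`: 13800 nM
Compound 2 `CCCSc1nc(N/N=C(\C)c2ccccc2O)c2nnn(Cc3ccccc3Cl)c2n1`: > 64000 nM
Compound 3 `CCCSc1nc(N/N=C(\C)c2ccccc2O)c2nnn(Cc3ccc(O)cc3)c2n1`: 9520 nM

In a functional assay on MCF7 cells (Homo sapiens) for antiproliferative activity, read by MTT assay, with a stated time of 72 h (on this read-out higher numbers stand for weaker inhibition and lower numbers for stronger inhibition), compound 1 gives 13800 nM, the highest of the two numbers shown, while compound 3 gives 9520 nM, within the scatter of compound 1. Compound 2 reaches only a limit of the assay, > 64000 nM (the limit of > 64000 nM in this assay, at which 1 of the 3 values shown sits). The single step shown, an at least 6.7-fold lower number from compound 2 to compound 3 (0.82 log units; beyond the scatter), concerns the group on the saturated chain carbon, not the hydrazone aryl.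

Compound 4 `CCCSc1nc(N/N=C/c2c(O)ccc3ccccc23)c2nnn(Cc3ccccc3)c2n1` differs from compound 1 by 2-hydroxynaphthalen-1-yl in place of 2-chlorophenyl on a carbon with a double bond to nitrogen. Within the data shown here, no measured step bears on this position, so compound 4 is expected to stay close to compound 1, with a step of a 1.4-fold lower number from compound 1 to compound 4 (0.14 log units; within the scatter). The estimate for compound 4 is 10000 nM, between 3000 nM and 40000 nM.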

Compound 4, half-maximal inhibitory concentration: 6400 nM
For compound 4 the middle estimate is 1.6-fold (0.19 log units) above the measured one; the measured number falls inside the stated range.
By their numbers in this assay, from the lowest: compounds 4, 3 and 1 (each within the scatter of the next, the first and the last beyond it). At a limit, above all of these: compound 2.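

On a carbon with a double bond to nitrogen, 2-hydroxynaphthalen-1-yl in place of 2-chlorophenyl gives a 2.2-fold lower number from compound 1 to compound 4 (0.33 log units; beyond the scatter) in this assay, the first step shown at this position. The position therefore responds to its aryl group, though modestly, and it accepts the larger two-ring group. Nothing given here explains this step.

The swap removes chlorine and adds both a hydroxyl and a second ring, so the compounds shown leave open which of these changes matters. Plain naphthalen-1-yl or 2-methoxynaphthalen-1-yl at this position could separate them.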